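The compounds below may be only part of what the source reports. "The series", "measured", "known", "first", "only" and "open" are said of these compounds alone.

Compounds measured so far in a functional assay on DU-145 cells (Homo sapiens) for inhibition, read by trypan blue exclusion, with a stated time of 96 h; a higher number here means a weaker inhibitor of growth, a lower number a stronger inhibitor of growth:

compound 1, `COc1ccc(/C=C(/Sc2ccc(Br)cc2)C(=O)c2ccc(Cl)cc2)cc1`: 50000 nM
compound 2, `O=C(/C(=C\c1ccc(Br)cc1)Sc1ccc(Br)cc1)c1ccc(Cl)cc1`: 1000 nM
compound 3, `Cc1ccc(CS/C(=C/c2ccc(Br)cc2)C(=O)c2ccc(Cl)cc2)cc1`: 10000 nM

Of these three, compound 2 gives the lowest number in this assay. Compound 3 stands nearest to it, the step being a 10-fold higher number from compound 2 to compound 3 (1.00 log units; beyond the scatter), and compound 1 stands furthest, as a 50-fold lower number from compound 1 to compound 2 (1.70 log units; beyond the scatter) shows.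

Compound 4, `O=C(/C(=C\c1c(O)cc(O)cc1O)Sc1ccc(Br)cc1)c1ccc(Cl)cc1`, has not yet been measured in this assay. Its change from compound 2 is 2,4,6-trihydroxyphenyl in place of 4-bromophenyl on a double-bonded chain carbon bound to a double-bonded chain carbon. Within the data shown here, the one measured step that touches this same ring is a 50-fold lower number from compound 1 to compound 2 (1.70 log units; beyond the scatter), where a methoxy on that ring gave way to bromo and the number fell by a large amount. The step of a 10-fold higher number from compound 2 to compound 3 (1.00 log units; beyond the scatter) concerns the group on sulfur and bears only indirectly. Since compound 4 puts oxygen-bearing substituents back on that ring, and three of them, the number in this assay is expected to rise well beyond the scatter, by about a 20-fold higher number from compound 2 to compound 4 (1.30 log units; beyond the scatter). Compound 4 is therefore estimated at 20000 nM, in the range 3000 nM to 100000 nM.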

Compound 4, concentration for 50% growth inhibition: 50000 nM
For compound 4 the middle estimate is 2.5-fold (0.40 log units) below the measured one, within the range that was stated.
By their numbers in this assay, from the lowest: compound 2; then compound 3; then compounds 1 and 4 (each within the scatter of the next).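

In this assay, the replacement of 4-bromophenyl by 2,4,6-trihydroxyphenyl on a double-bonded chain carbon bound to a double-bonded chain carbon gives a 50-fold higher number from compound 2 to compound 4 (1.70 log units; beyond the scatter) and so shows that a second group at this place, one carrying hydroxyl groups instead of a methoxy, also ends far from compound 2. Against the 4-methoxyphenyl group, the same group gives no change at the digits printed from compound 1 to compound 4 (within the scatter) and so the two oxygen-bearing groups cannot be told apart here, whether the ring holds one methoxy or three hydroxyl groups. Nothing measured here accounts for this result.

As far as these compounds go, whether chloro, fluoro or an amine in place of the bromo of compound 2 would stay near compound 2 or join compounds 1 and 4 remains open. Also open, from the compounds shown here alone, is how 2,4,6-trihydroxyphenyl would behave with the 4-methylbenzyl on sulfur of compound 3.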